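From a Methylphenyl Arm to a Cyclopentyl Arm

The compounds below may be only part of what the source reports. "The series", "measured", "known", "first", "only" and "open" are said of these compounds alone.

Compound 1 `Cc1ccc(Cn2c(CN3CCN(C(=O)C4CC4)CC3)nc3ccccc32)cc1` was tested in an assay on isolated protein for inhibition of aldehyde dehydrogenase 1A1 (Homo sapiens), read by spectrophotometry, tested at 10 uM (on this read-out lower numbers stand for less inhibition and higher numbers for more inhibition at the one concentration tested (going by the name of the read-out)), where compound 1 gives 51.5%. Of the three measured compounds this is the lowest number: compound 2 `Cc1cccc(Cn2c(CN3CCN(C(=O)c4cccs4)CC3)nc3ccccc32)c1` gives 60.8%, a gap within the scatter, and compound 3 `Cc1ccc(C(=O)N2CCN(Cc3nc4ccccc4n3Cc3cccc(C)c3)CC2)cc1` gives 64.9%, a gap beyond it. Going by the values given here, the one measured step, a number 4.1 percentage points higher from compound 2 to compound 3 (within the scatter), alters the group on the carbonyl carbon, not the arm on the ring nitrogen. Compound 4 `O=C(C1CC1)N1CCN(Cc2nc3ccccc3n2CC2CCCC2)CC1` differs from compound 1 on that other side: cyclopentyl in place of 4-methylphenyl on a saturated chain carbon bound to an aromatic nitrogen. Cut one bond further out, this reads 4-methylbenzyl to cyclopentylmethyl. Among the compounds with values here, no measured step covers this part of the molecule, so the data give no direction. Compound 4 is therefore expected close to compound 1, at 47% within 27% to 67%. The expected step of a number 4.5 percentage points lower from compound 1 to compound 4 (within the scatter) stays within the scatter.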

Compound 4, a percentage reported as inhibition, at one concentration (the size of the read-out at that concentration, not a potency): 44.5%
The estimate for compound 4 lay 2.5 percentage points above the measured number, within the range that was stated.
By their numbers in this assay, from the lowest: compounds 4, 1, 2 and 3 (each within the scatter of the next, the first and the last beyond it).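

On the saturated chain carbon bound to an aromatic nitrogen, putting cyclopentyl in place of 4-methylphenyl gives a number 7 percentage points lower from compound 1 to compound 4 (within the scatter). For this pair, then, a five-membered non-aromatic ring of carbon only can replace the six-membered aromatic ring without a change beyond the scatter. No available evidence bears on this result.

Still open, on these data alone, is whether an amine or a carboxylic acid on this arm, or a longer chain in place of cyclopentylmethyl, would leave the number as little changed. As far as these compounds go, it is also open whether cyclopentyl would behave the same way with thiophen-2-yl or 4-methylphenyl on the carbonyl carbon.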